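This account rests on a few compounds, and the source may have more. Where it says the series, first, only, none or still open, it means among the compounds named here.

Working notes on the series. In a physicochemical assay for lipophilicity (on this read-out higher numbers stand for higher lipophilicity and lower numbers for lower lipophilicity), compound 3 `O=S(=O)(Nc1nccs1)c1ccc2c(c1)OCC[C@@H]2c1ccc(C(F)(F)F)cc1-c1ccc(F)cc1` stands highest of the three measured compounds at 4.5. Compound 2 `Cc1nc(-c2cc(C(F)(F)F)ccc2[C@@H]2CCOc3cc(S(=O)(=O)Nc4nccs4)ccc32)co1` gives 2.9, and compound 1 `O=S(=O)(Nc1nccs1)c1ccc2c(c1)OCC[C@H]2c1ccc(C(F)(F)F)cc1-n1ccnn1` gives 2.3. Both lie beyond the scatter from compound 3.

Compound 4 `O=S(=O)(Nc1nccs1)c1ccc2c(c1)OCC[C@H]2c1ccc(C(F)(F)F)cc1-c1ccc(F)cc1` is read against compound 3, and the structural change is this: the two compounds have the same atoms and bonds and differ only in configuration as drawn: 1 of 1 stereo elements differ; a stereocentre at a saturated ring carbon is drawn R in compound 3 and S in compound 4. Nothing leaves and nothing enters.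

Among the measured compounds shown here, the only measured step between compounds differing in one place is a number 0.60 log units higher from compound 1 to compound 2 (beyond the scatter), with 2-methyl-1,3-oxazol-4-yl in place of 1H-1,2,3-triazol-1-yl on an aromatic carbon. That step is modest, but it replaces one group with another, so it gives no size for a change of configuration alone. For the measured compounds named here, no measured pair isolates such a change, and the expectation therefore rests on the structural comparison itself: the same atoms and bonds, with only the stereocentre drawn differently.

No step beyond the scatter is expected in this assay, and the reference point is compound 3 at 4.5. The expected step is no change at the digits printed from compound 3 to compound 4 (within the scatter). For compound 4 the estimated value is 4.5, with an expected range from 4.2 to 4.8.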

Compound 4, distribution coefficient: 4.5
Compound 4: the middle estimate sits on the measured number at the digits printed; measured number inside the range.
By their numbers in this assay, from the lowest: compound 1; then compound 2; then compounds 3 and 4 (each within the scatter of the next).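

In this assay, among the compounds shown here, the change of the stereocentre at the saturated ring carbon from R to S gives no change at the digits printed from compound 3 to compound 4 (within the scatter), the first reading of a change of configuration alone: the fact that compounds 3 and 4 differ only in the configuration as drawn. Compound 4 also serves as a common reference for the group on the aromatic carbon: 4-fluorophenyl in place of 2-methyl-1,3-oxazol-4-yl gives a number 1.60 log units higher from compound 2 to compound 4 (beyond the scatter), and 4-fluorophenyl in place of 1H-1,2,3-triazol-1-yl gives a number 2.20 log units higher from compound 1 to compound 4 (beyond the scatter). Set against a number 0.60 log units higher from compound 1 to compound 2 (beyond the scatter), these steps show that, among these four compounds, exchanging the group on that aromatic carbon moves the number, while changing the stereocentre leaves it within the scatter.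

Whether the stereocentre is equally silent with 2-methyl-1,3-oxazol-4-yl or 1H-1,2,3-triazol-1-yl on the aromatic carbon stays open, as the compounds shown offer a configuration pair only with 4-fluorophenyl. Also open, on these data alone, is where a carboxylic acid or an aminomethyl group on that carbon would stand in this assay, and whether the two configurations stay level on any other read-out.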